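Benzyloxy to (tert-butyl)amino on the carbonyl carbon

The source may hold more compounds than are shown below. What is called first, only, known or untested is meant among the compounds shown, and "the series" means these compounds.

In an assay on isolated protein with Bile acid receptor (Homo sapiens) as the target (on this read-out higher numbers stand for an effect only at larger amounts of compound and lower numbers for an effect already at smaller amounts), compound 3 `COC(=O)/C=C/c1cccc(N(Cc2ccc(/C=C/C(=O)OCc3ccccc3)cc2)C(=O)C2CCCCC2)c1` gives > 1000 nM, which is a limit of the assay and not a number. Compound 1 `COC(=O)/C=C/c1cccc(N(Cc2ccc(C(C)(C)C)cc2)C(=O)C2CCCCC2)c1` likewise gives only a limit, > 1000 nM. Compound 2 `COC(=O)/C=C/c1ccc(CN(C(=O)C2CCCCC2)c2cccc(/C=C/C(=O)OC)c2)cc1` also reaches only a limit, > 1000 nM. All three values sit at the limit of > 1000 nM in this assay, at which 3 of the 3 values shown sit, so the steps a step that the two limits leave unreadable from compound 1 to compound 2, a step that the two limits leave unreadable from compound 1 to compound 3 and a step that the two limits leave unreadable from compound 2 to compound 3 cannot be read in size or direction. Compound 4 `COC(=O)/C=C/c1cccc(N(Cc2ccc(/C=C/C(=O)NC(C)(C)C)cc2)C(=O)C2CCCCC2)c1` differs from compound 3 by (tert-butyl)amino in place of benzyloxy on a carbonyl carbon. For the measured compounds named here, no measured step replaces benzyloxy with (tert-butyl)amino, and no measured step is readable, so the series gives no direction for this change. Compound 4 is therefore expected to remain at the limit, with the step that the limit leaves unreadable from compound 3 to compound 4 estimated as none beyond the scatter. The estimate for compound 4 is 3000 nM, between 1000 nM and 10000 nM.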

Compound 4, half-maximal effective concentration: > 1000 nM
Compound 4: no number, only a limit; the forecaster's own chance of this, stated with the estimate: 80%; the middle value lies beyond the limit too.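

The steps from compound 1, compound 2 and compound 3 to compound 4 cannot be read, since all four values are limits, not numbers: the limit of > 1000 nM in this assay, at which 4 of the 4 values shown sit. The compounds shown leave open how any of these replacements affects the effective concentration.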